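The source may report more compounds than this note shows. Statements on the series, on what has been measured and on what is new or still open speak of the compounds shown alone.

Measured so far in a functional assay on MDA-MB-231 cells (Homo sapiens) for inhibition (on this read-out higher numbers stand for weaker inhibition and lower numbers for stronger inhibition), are these compounds:
- compound 1 `O=C(NO)c1ccc(-c2ccc(CNCc3ccccc3Cl)cn2)s1` gives 170 nM in this series
- compound 2 `O=C(NO)c1ccc(-c2ccc(CNCc3ccc(Cl)cc3)cn2)s1` gives 300 nM in this series
- compound 3 `O=C(NO)c1ccc(-c2ccc(CNCCCc3ccccc3)cn2)s1` gives 250 nM in this series

Compound 2 does not stand apart from the other two. Within the data shown here, the comparison with compound 1 shows a 1.8-fold higher number from compound 1 to compound 2 (0.25 log units; within the scatter) and the one with compound 3 shows a 1.2-fold lower number from compound 2 to compound 3 (0.08 log units; within the scatter) as the remaining gap.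

Next is compound 4 `O=C(NO)c1ccc(-c2ccc(CNc3ccccc3)cn2)s1`, which carries phenyl in place of 4-chlorobenzyl on an amine nitrogen. Among the measured compounds shown here, no measured compound has its phenyl directly on the amine nitrogen, so no measured step matches this change. The nearest evidence is the set of swaps in the group on the amine nitrogen. These include a 1.5-fold higher number from compound 1 to compound 3 (0.17 log units; within the scatter) alongside the two steps above, and all three stay within the scatter. On that basis, no step beyond the scatter is expected in this assay, and no direction is favoured. The untested attachment still argues for a wide range.

Expected for the step is a 1.1-fold lower number from compound 2 to compound 4 (0.03 log units; within the scatter) as the working estimate. For compound 4 the estimated value is 280 nM with an expected range from 100 nM to 800 nM in this assay.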

Compound 4, half-maximal inhibitory concentration: 630 nM
The estimate for compound 4 lay 2.3-fold (0.35 log units) below the measured number; the range from low to high includes it.
By their numbers in this assay, from the lowest: compounds 1, 3 and 2 (each within the scatter of the next); then compound 4.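

In this assay, the group on the amine nitrogen gives its first steps beyond the scatter: phenyl in place of 4-chlorobenzyl gives a 2.1-fold higher number from compound 2 to compound 4 (0.32 log units; beyond the scatter) and phenyl in place of 2-chlorobenzyl gives a 3.7-fold higher number from compound 1 to compound 4 (0.57 log units; beyond the scatter), both modest. Compounds 1, 2 and 3 all have a saturated chain carbon on the amine nitrogen and stay within the scatter of one another despite their different chlorine placement and chain length, whereas compound 4, with its phenyl directly on that nitrogen, is the only one to stand apart from compounds 1 and 2. Nothing available explains these steps.

Each step removes both the saturated chain carbon and the chlorine, so the shown compounds cannot assign the weaker inhibition of compound 4 to either change; unsubstituted benzyl or 4-chlorophenyl on the amine nitrogen would separate the two. On these data alone, how far this position extends beyond aromatic groups also remains open, for example with a cyclohexylmethyl group on the amine nitrogen.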